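This account rests on a few compounds, and the source may have more. Where it says the series, first, only, none or still open, it means among the compounds named here.

Measured so far in a functional assay on Raji cells (Homo sapiens) for antiproliferative activity, read by CCK-8 assay, with a stated time of 72 h, tested at 40 uM; on this read-out higher numbers stand for more inhibition at the one concentration tested (going by the name of the read-out) and lower numbers for less inhibition:

- compound 1, `CCOC(=O)c1sc(-c2cccc(NC(=O)c3cccc(F)c3)c2)nc1Nc1ccc(N2CCN(C)CC2)cc1`: compound 1 gives 82.8%
- compound 2, `CCOC(=O)c1sc(-c2cccc(NC(=O)c3ccccc3F)c2)nc1Nc1ccc(N2CCN(C)CC2)cc1`: compound 2 gives 89.8%
- compound 3, `CN1CCN(c2ccc(Nc3nc(-c4cccc(NC(=O)c5cccc(F)c5)c4)sc3C(N)=O)cc2)CC1`: compound 3 gives 2.78%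

Compound 4, `CN1CCN(c2ccc(Nc3nc(-c4cccc(NC(=O)c5ccccc5F)c4)sc3C(N)=O)cc2)CC1`, is the one still to be measured in this assay.

Compounds 1 and 2 share one core; compounds 3 and 4 share another. The two cores differ as amino in place of ethoxy on a carbonyl carbon, and that change gave a number 80 percentage points lower from compound 1 to compound 3 (beyond the scatter), the largest step in the set; compound 3 stands lowest of the three measured compounds.

The change from compound 3 to compound 4 is 2-fluorophenyl in place of 3-fluorophenyl on a carbonyl carbon. The same change is made from compound 1 to compound 2, (2-fluorophenyl in place of 3-fluorophenyl on a carbonyl carbon), and there it gave a number 7 percentage points higher from compound 1 to compound 2 (within the scatter). The place around the change reads the same in both pairs, so it is the same change, seen twice among these compounds.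

For compound 4 the step of a number 5.2 percentage points higher from compound 3 to compound 4 (within the scatter) is expected to be small, resting on compound 1 to compound 2, where the change gave a number 7 percentage points higher from compound 1 to compound 2 (within the scatter), and on compound 3 sitting at 2.78%, leaving little room downward. The estimate for compound 4 in this assay is therefore 8%, between 0% and 25%.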

Compound 4, a percentage reported as inhibition, at one concentration (the size of the read-out at that concentration, not a potency): 97.3%
Beside the measured number, compound 4's estimate is 89.3 percentage points below it; measured number outside the range, above it.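

In this assay, 2-fluorophenyl in place of 3-fluorophenyl on a carbonyl carbon gave a number 94.5 percentage points higher from compound 3 to compound 4 (beyond the scatter) on the core carrying the amino group, so the size of this step did not carry over from the core carrying the ethoxy group: the same change on two cores in this assay, a number 7 percentage points higher (within the scatter) from compound 1 to compound 2 and a number 94.5 percentage points higher (beyond the scatter) from compound 3 to compound 4, 87.5 percentage points apart, beyond the scatter of two such steps. Amino in place of ethoxy on a carbonyl carbon gave a number 7.5 percentage points higher from compound 2 to compound 4 (within the scatter) with 2-fluorophenyl present, so the large drop seen with 3-fluorophenyl did not carry over either: the same change on two cores in this assay, a number 80 percentage points lower (beyond the scatter) from compound 1 to compound 3 and a number 7.5 percentage points higher (within the scatter) from compound 2 to compound 4, 87.5 percentage points apart, beyond the scatter of two such steps. Within the data shown here, in these four compounds neither change can be read apart from the other, but the pattern rests on the single low value of compound 3, 2.78%, and the numbers do not show what lies behind it.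

The compounds shown leave open whether a carboxylic acid or a methylamide in place of ethoxy, or an unsubstituted phenyl in place of the fluorophenyl, would follow the same pattern. Inhibition at one concentration also leaves the potency of all four compounds open.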